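The compounds below may be only part of what the source reports. "The series", "measured", "known", "first", "only" and "open" are said of these compounds alone.

Measured compounds:
Compound 1 `C=C[C@@](C)(/C=C/c1ccc(OC)cc1)CCC=C(C)C` — in a functional assay on Raji cells (Homo sapiens) for cytotoxicity, with a stated time of 72 h (on this read-out higher numbers stand for an effect only at larger amounts of compound and lower numbers for an effect already at smaller amounts), compound 1 gives > 26000 nM, a limit of the assay rather than a number.
Compound 2 `C=C[C@@](C)(/C=C/c1ccc(Nc2cc(C(F)(F)F)cc(C(F)(F)F)c2)cc1)CCC=C(C)C` — compound 2 gives > 26000 nM, likewise a limit and not a number.

Compound 1 therefore stands nowhere definite on the numbers shown: its result is a limit, and the same is true of the only other value, so the picture is the limit of > 26000 nM in this assay, at which 2 of the 2 values shown sit. For the measured compounds named here, no step between measured compounds can be drawn from this.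

Compound 3 `C=C[C@@](C)(/C=C/c1ccc(-c2cccc(F)c2)cc1)CCC=C(C)C` is not yet measured. It differs from compound 1 by 3-fluorophenyl in place of methoxy on an aromatic carbon. Going by the values given here, with both measured values sitting at the same limit, there is no measured step on which to ground a direction; he expects a step that the limit leaves unreadable from compound 1 to compound 3, that is, no movement beyond the scatter and most likely a further limit. His estimate for compound 3 in this assay is 30000 nM, within 8000 nM to 100000 nM.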

Compound 3, half-maximal effective concentration: > 26000 nM
Compound 3: no number, only a limit; the forecaster's own chance of this, stated with the estimate: 70%; the middle value is on the limit's open side.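

For the compounds shown here, compound 3, like compound 1, gives only a limit and not a number, so no step from compound 1 to compound 3 can be read: the limit of > 26000 nM in this assay, at which 3 of the 3 values shown sit. The compounds shown leave open whether any change to the shared core would give a readable number in this assay.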